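The source may hold more compounds than are shown below. What is called first, only, known or untested is meant among the compounds shown, and "the series" means these compounds.

Measured compounds:

Compound 1, `CCC[C@]1(c2ccccc2)OC[C@H]([C@@H]2CCCCN2)O1`, gives 69 nM in a functional assay (brain) for displacement of a labelled ligand, with Rattus norvegicus as the target; a lower number here means a stronger inhibitor, a higher number a weaker inhibitor.
Compound 2, `CCCC[C@]1(c2ccccc2)OC[C@H]([C@@H]2CCCCN2)O1`, gives 200 nM in this assay.
Compound 3, `CN1CCCC[C@H]1[C@H]1COC(c2ccccc2)(c2ccccc2)O1`, gives 4400 nM in this assay.

Compound 1 and compound 2 share one core and differ at a single point: methyl in place of hydrogen on a saturated chain carbon, three bonds along the chain from a saturated ring carbon. This step, a 2.9-fold higher number from compound 1 to compound 2 (0.46 log units; beyond the scatter), shows that adding one carbon here weakens inhibition by a modest amount, clearly more than the usual scatter of the measurement.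

Compound 3 is built on a different core, and the difference between the two cores is not broken down here. Its number in this assay is the highest of the three, well beyond the scatter from both compound 1 and compound 2.

Compound 4, `CCN1CCCC[C@H]1[C@H]1COC(c2ccccc2)(c2ccccc2)O1`, has not yet been measured in this assay. It differs from compound 3 by methyl in place of hydrogen on a saturated chain carbon bound to an amine nitrogen in a ring. Among the compounds with values here, this is the same kind of change as the one from compound 1 to compound 2, since in both cases a methyl takes the place of a hydrogen on a saturated chain carbon. The surroundings differ, however: in compound 2 the place is three bonds along the chain from a saturated ring carbon, whereas in compound 4 the place is bound to an amine nitrogen in a ring. Within the data shown here, because the only measured precedent, a 2.9-fold higher number from compound 1 to compound 2 (0.46 log units; beyond the scatter), pointed toward weaker inhibition, a step of similar direction and size is expected here, a 2.0-fold higher number from compound 3 to compound 4 (0.31 log units; beyond the scatter), though a different place on a different core makes this uncertain. The number expected for compound 4 in this assay is 9000 nM, likely lying between 3000 nM and 27000 nM.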

Compound 4, inhibition constant: 6900 nM
For compound 4 the middle estimate is 1.3-fold (0.12 log units) above the measured one; the measured number falls inside the stated range.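

In this assay, lengthening the methyl on the ring nitrogen to an ethyl gives a 1.6-fold higher number from compound 3 to compound 4 (0.20 log units; within the scatter), so on this core the step alone cannot be told apart from the ordinary spread of repeated measurements. Set beside the step on the other core, the same kind of change gives no sign of behaving differently: the same change on two cores in this assay, a 2.9-fold higher number (0.46 log units; beyond the scatter) from compound 1 to compound 2 and a 1.6-fold higher number (0.20 log units; within the scatter) from compound 3 to compound 4, 1.8-fold (0.27 log units) apart, within the scatter of two such steps. Within the data shown here, this means the two results are compatible with the change carrying over from one core to the other, but it does not show that the effect is the same, since only two pairs are available, the added carbon sits in a different place in each, and only one of the two steps stands clear of the scatter.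

The compounds shown leave open how the trend continues on the core of compound 3, for example with a longer chain such as propyl on the ring nitrogen, or with a hydrogen there in place of the methyl of compound 3. They also leave open whether a shorter or branched chain in the place changed from compound 1 to compound 2 would follow the same direction.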